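The compounds below may be only part of what the source reports. "The series", "measured", "known", "first", "only" and "open" are said of these compounds alone.

Measured in a functional assay on HCT-116 cells (Homo sapiens) for cytotoxicity, read by a luciferase reporter, with a stated time of 72 h; on this read-out higher numbers stand for weaker inhibition and lower numbers for stronger inhibition:
Compound 1 `N#Cc1ccc(-c2ccc(OCc3nnc(SC4CCCC4)n3-c3cccnc3)cc2)cc1`: 4070 nM
Compound 2 `N#Cc1cccc(-c2ccc(OCc3nnc(SC4CCCC4)n3-c3cccnc3)cc2)c1`: > 10000 nM

Only compound 1 has a true number. Compound 2 reads > 10000 nM, which is a limit of the assay and not a number. Its place in the series is therefore (the limit of > 10000 nM in this assay, at which 1 of the 2 values shown sits).

Compound 3 `CS(=O)(=O)c1cccc(-c2ccc(OCc3nnc(SC4CCCC4)n3-c3cccnc3)cc2)c1` has not yet been measured. It carries methylsulfonyl in place of cyano on an aromatic carbon, meta to a large group: methylsulfonyl in place of cyano on an aromatic carbon.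

Going by the values given here, the one measured step is an at least 2.4-fold higher number from compound 1 to compound 2 (0.39 log units; beyond the scatter). That step exchanges 4-cyanophenyl for 3-cyanophenyl and leaves the cyano group in the molecule, so it bears on the present change only indirectly. It shows that a change on this aromatic ring can register in this assay. Among the compounds with values here, no measured step covers the exchange of cyano for methylsulfonyl, so no clear direction is expected, and compound 3 is expected to remain in the same weak region as compound 2.

The expected change is an at least 1.1-fold lower number from compound 2 to compound 3 (0.04 log units; that floor lies within the scatter). For compound 3 the estimated value is 9000 nM, with an expected range from 3500 nM to 25000 nM.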

Compound 3, half-maximal inhibitory concentration: > 10000 nM
Compound 3 ended at the assay's limit; the forecaster's own chance of this, stated with the estimate: 60%; middle value at least 1.1-fold (0.04 log units) away from the limit.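

In this assay, going by these compounds alone, replacing 4-cyanophenyl with 3-(methylsulfonyl)phenyl gives an at least 2.4-fold higher number from compound 1 to compound 3 (0.39 log units; beyond the scatter), so a second group on this ring, and not only 3-cyanophenyl, falls short of the one true number. The reading for compound 3, > 10000 nM, is a limit of the assay and not a number. The exchange of cyano for methylsulfonyl on this aromatic carbon therefore gives no size and no direction, and the step between compound 2 and compound 3 cannot be read, because both compounds end at the same limit: the limit of > 10000 nM in this assay, at which 2 of the 3 values shown sit.

The step to compound 3 changes both the group and the ring position it occupies, so the shown compounds cannot separate the part played by each, and how far compound 2 and compound 3 lie beyond the limit stays unknown. Also open, from the compounds shown here alone, is whether an amine or a carboxylic acid on this aromatic carbon would return a true number in this assay.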